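Amide replacement on the shared core: compound 2 to compound 4

A few compounds are considered here, and "the series" means these few. Any claim that something is new, unique, unknown or untested is made for them only; others in the source may bear on it.

Measured so far:
compound 1 `Cn1c(/C=C2\SC(=O)N(CC(=O)Nc3cc(C(C)(C)C)on3)C2=O)nc2ccccc21` gives 31400 nM in a functional assay on DU-145 cells (Homo sapiens) for inhibition, read by MTT assay, with a stated time of 48 h; on this read-out lower numbers stand for stronger inhibition and higher numbers for weaker inhibition.
compound 3 `COc1cc2c(cc1OC)CN(C(=O)CN1C(=O)S/C(=C\c3nc4ccccc4n3C(C)C)C1=O)CC2` gives 29700 nM in this assay.
compound 2 `CC(C)n1c(/C=C2\SC(=O)N(CC(=O)N3CCCC3)C2=O)nc2ccccc21` gives only a limit, > 50000 nM, in this assay.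

Compound 2 stands at the limit of this assay and not at a number, the case noted as the limit of > 50000 nM in this assay, at which 1 of the 3 values shown sits. Compound 1 and compound 3 sit at measured numbers, both weak on this read-out.

Compound 4 `CC1CN(C(=O)CN2C(=O)S/C(=C\c3nc4ccccc4n3C(C)C)C2=O)CC(C)O1` differs from compound 2 in one place: 2,6-dimethylmorpholin-4-yl in place of pyrrolidin-1-yl on a carbonyl carbon. Among the compounds with values here, no measured pair isolates this change, so no step is known for it. Compound 1 and compound 3 show that varied amide groups on this core stay weak. The step from compound 2 to compound 4 in this assay is therefore expected to be no larger than the scatter, in either direction. Compound 4 is expected near 45000 nM, range 20000 nM to 100000 nM. This corresponds to an expected step of an at least 1.1-fold lower number from compound 2 to compound 4 (0.04 log units; that floor lies within the scatter), with a fair chance the assay again reports only a limit for compound 4.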

Compound 4, half-maximal inhibitory concentration: > 50000 nM
Compound 4: a limit, no number; the forecaster's own chance of this, stated with the estimate: 50%; middle value at least 1.1-fold (0.04 log units) away from the limit.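

Compound 2 and compound 4 both give only a limit, so no step can be read between them: the limit of > 50000 nM in this assay, at which 2 of the 4 values shown sit.

As far as these compounds go, whether 2,6-dimethylmorpholin-4-yl and pyrrolidin-1-yl differ in effect on the shared core stays open.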